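Replacing Ethyl with Benzoyl on the Ring Nitrogen

This account rests on a few compounds, and the source may have more. Where it says the series, first, only, none or still open, it means among the compounds named here.

Compound 1: `CCN1CCCC(NC(=O)c2c(OC)cc(C(F)(F)F)cc2C(F)(F)F)(c2ccccc2)C1` gives 230 nM in an assay on cells for inhibition of sodium- and chloride-dependent glycine transporter 1 (Homo sapiens); a lower number here means that less compound is needed, a higher number that more compound is needed for the effect.
Compound 2: `COc1cc(C(F)(F)F)cc(C(F)(F)F)c1C(=O)NC1(c2ccccc2)CCCN(CC2CC2)C1` gives 380 nM in this assay.
Compound 3: `COc1cc(C(F)(F)F)cc(C(F)(F)F)c1C(=O)NC1(c2ccccc2)CCCN(Cc2ccccc2)C1` gives 6700 nM in this assay.

Three compounds share one core and differ only in the group attached to the amine nitrogen in the ring. Compound 1 has the lowest number of the three; compound 2 sits close to it, with a 1.7-fold higher number from compound 1 to compound 2 (0.22 log units; within the scatter), a step within the scatter. Compound 3 stands far away: a 29-fold higher number from compound 1 to compound 3 (1.46 log units; beyond the scatter), and an 18-fold higher number from compound 2 to compound 3 (1.25 log units; beyond the scatter), both large.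

Compound 4 is `COc1cc(C(F)(F)F)cc(C(F)(F)F)c1C(=O)NC1(c2ccccc2)CCCN(C(=O)c2ccccc2)C1`. Compared with compound 1 it carries benzoyl in place of ethyl on an amine nitrogen in a ring. The nearest guide is the step to compound 3, where a six-membered aromatic ring of carbon entered at the carbon next to that nitrogen and the number rose sharply. Compound 4 likewise gains such a ring, this time within a benzoyl placed directly on the nitrogen, so a large rise in the number is expected, on the order of a 26-fold higher number from compound 1 to compound 4 (1.42 log units; beyond the scatter). Compound 4 is therefore estimated at 6000 nM, within a range from 1500 nM to 25000 nM.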

Compound 4, half-maximal effective concentration: > 10000 nM
Compound 4: only a limit was reported; the forecaster's own chance of this, stated with the estimate: 15%; middle value at least 1.6-fold (0.22 log units) from the limit.
By their numbers in this assay, from the lowest: compounds 1 and 2 (each within the scatter of the next); then compound 3. At a limit, above all of these: compound 4.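

In this assay compound 4 reaches only a limit, > 10000 nM. The change to benzoyl on the amine nitrogen in a ring is large, with an at least 43-fold higher number from compound 1 to compound 4 (1.63 log units; beyond the scatter) and an at least 26-fold higher number from compound 2 to compound 4 (1.42 log units; beyond the scatter), so a carbonyl joining the six-membered aromatic ring at this position does not bring the number back towards those of the ethyl and cyclopropylmethyl compounds. Against the benzyl compound the step is an at least 1.4-fold higher number from compound 3 to compound 4 (0.17 log units; that floor lies within the scatter), so benzoyl and benzyl cannot be told apart here, and the real distance stays unknown because the reading stops at a limit: the limit of > 10000 nM in this assay, at which 1 of the 4 values shown sits.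

The compounds shown leave open whether the high numbers follow the aromatic ring, the carbonyl or simply the larger group. An acetyl group on this nitrogen would test the carbonyl without the ring, and a cyclohexylmethyl group would test a large group without aromaticity.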